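The source may report more compounds than this note shows. Statements on the series, on what has been measured and on what is new or still open speak of the compounds shown alone.

Measured compounds:
- compound 1 `Nc1ccccc1NC(=O)c1ccc(CSC(=S)N2CCN(Cc3ccncc3)CC2)cc1`: in a functional assay on MGC-803 cells (Homo sapiens) for antiproliferative activity, read by CCK-8 assay, with a stated time of 72 h, tested at 8 uM (on this read-out higher numbers stand for a stronger effect at the one concentration tested and lower numbers for a weaker effect), compound 1 gives 79.3%.
- compound 2 `CN1CCN(C(=S)SCc2ccc(C(=O)Nc3ccccc3N)cc2)CC1`: in this assay compound 2 gives 84.4%.
- compound 3 `Nc1ccccc1NC(=O)c1ccc(CSC(=S)N2CCN(Cc3cccnc3)CC2)cc1`: in this assay compound 3 gives 64.6%.

Compound 3 stands lowest of the three numbers; the step of a number 14.7 percentage points lower from compound 1 to compound 3 (beyond the scatter) and the step of a number 19.8 percentage points lower from compound 2 to compound 3 (beyond the scatter) both lie beyond the scatter, whereas a number 5.1 percentage points higher from compound 1 to compound 2 (within the scatter) does not. Compound 4 `Nc1ccccc1NC(=O)c1ccc(CSC(=S)N2CCN(C3CCCCC3)CC2)cc1` is not yet measured; it differs from compound 3 in that (cyclohexyl in place of (pyridin-3-yl)methyl on an amine nitrogen in a ring). Within the data shown here, no measured step swaps the (pyridin-3-yl)methyl group for cyclohexyl, so none bears on it directly. Among the measured compounds shown here, the only step touching this ring nitrogen in the same sense is a number 19.8 percentage points lower from compound 2 to compound 3 (beyond the scatter), which shows that taking the pyridin-3-yl away from the saturated chain carbon bound to the ring nitrogen is tied to a modest rise. For the measured compounds named here, on that basis a modest rise is expected for compound 4 rather than no step, with wide uncertainty. The step expected for compound 4 is a number 9.4 percentage points higher from compound 3 to compound 4 (within the scatter). Compound 4 is estimated at 74%, within 58% to 88%.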

Compound 4, a percentage reported as inhibition, at one concentration (the size of the read-out at that concentration, not a potency): 75.3%
The estimate for compound 4 lay 1.3 percentage points below the measured number; measured number inside the range.
By their numbers in this assay, from the lowest: compound 3; then compounds 4, 1 and 2 (each within the scatter of the next).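

In this assay, an all-carbon ring placed directly on the amine nitrogen in a ring is compatible with a read-out outside the range of compound 3: cyclohexyl in place of (pyridin-3-yl)methyl gives a number 10.7 percentage points higher from compound 3 to compound 4 (beyond the scatter). Compared with the other two substituents, the change gives a number 9.1 percentage points lower from compound 2 to compound 4 (within the scatter) and a number 4 percentage points lower from compound 1 to compound 4 (within the scatter), so among the compounds shown only compound 3 stands apart, with its steps to all three others beyond the scatter. Nothing available explains why compound 3 stands apart.

This step changes the ring type and removes the saturated chain carbon at once, so the two changes cannot be separated; benzyl and cyclohexylmethyl groups at this nitrogen would address that. Results at a single concentration also leave relative potency across the series open.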